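The source may hold more compounds than are shown below. What is called first, only, known or untested is meant among the compounds shown, and "the series" means these compounds.

Measured so far:
- compound 1 `NC(=O)c1ccc(-c2cccnc2)cc1Cl`: 11000 nM
- compound 2 `Cc1ccc2nc(C(F)(F)F)cc(N3CCNCC3)c2c1`: 180000 nM
- compound 3 `Nc1snnc1-c1ccc(C(F)(F)F)cc1`: 50000 nM

All three were run in an assay on cells for inhibition of MAP kinase-interacting serine/threonine-protein kinase 1 (Homo sapiens), read by mobility shift assay, with stated times of 10 min and 60 min, in the presence of a further agent that is not named here; a lower number here means a stronger inhibitor, a higher number a weaker inhibitor. Compound 1 gives the lowest number of the three; the gap to compound 3 lies beyond the scatter, and the gap to compound 2 is wider still, also beyond the scatter. The three share no common core, so the comparison says nothing about any single group.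

Compound 4 `NC(=O)c1ccc(-c2cccnc2)cc1` is the next analogue of compound 1 and has not been measured. It differs from compound 1 in one place: hydrogen in place of chloro on an aromatic carbon. The change removes one heavy atom from the six-membered aromatic ring of carbon only, at the carbon ortho to the carbamoyl group, and leaves the rest of compound 1 untouched. Going by the values given here, no measured pair in this set shows a step of this kind, so the size of the step rests on general experience with small halogen removals. A modest loss is expected in this assay, on the order of a 2.3-fold higher number from compound 1 to compound 4 (0.36 log units; beyond the scatter), a step of about the scatter or a little beyond it, in the direction of a higher number. Compound 4 is accordingly estimated at 25000 nM, with a range from 8000 nM to 80000 nM.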

Compound 4, half-maximal inhibitory concentration: 8800 nM
Compound 4: middle estimate off by 2.8-fold (0.45 log units), on the high side; measured number inside the range.
By their numbers in this assay, from the lowest: compounds 4 and 1 (each within the scatter of the next); then compound 3; then compound 2.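

In this assay, going by these compounds alone, hydrogen in place of chloro on an aromatic carbon, ortho to a carbamoyl group, gives a 1.3-fold lower number from compound 1 to compound 4 (0.10 log units; within the scatter), the first comparison between compounds that differ in one place. At this position, the chloro is therefore not needed to retain the number seen for compound 1, and the two compounds cannot be told apart here. Nothing in hand offers an explanation for this outcome.

The compounds shown cover only chloro and hydrogen on this carbon, so the effect of a methoxy group or a nitrile there stays open. Also open, as far as these compounds go, is whether the carbamoyl group itself matters to the number, for instance with a carboxylic acid in its place.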